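The source may hold more compounds than are shown below. What is called first, only, known or untested is meant among the compounds shown, and "the series" means these compounds.

Three compounds built on a shared core were tested in an ADME assay on MDBK cells (Bos taurus) for cytotoxicity, read by MTT assay, with a stated time of 96 h; a lower number here means that less compound is tolerated, a higher number that more compound is tolerated. Compound 1 `CC(=O)Nc1ccc(-c2nc3cc(C(F)(F)F)ccc3n2C)cc1` gives 46000 nM, and compound 2 `Oc1ccc(-c2nc3cc(Cl)c(Cl)cc3[nH]2)cc1` gives 11000 nM. For compound 3 `O=C(O)CCC(=O)Nc1ccc(-c2nc3cc(C(F)(F)F)ccc3[nH]2)cc1` this assay reports only a limit, > 100000 nM, which is one of the values sitting at the limit of > 100000 nM in this assay, at which 1 of the 3 values shown sits; compound 3 thus stands at the most tolerated end of the numbers shown, without a number of its own. Compound 4 `COc1ccc(-c2nc3cc(C(F)(F)F)ccc3[nH]2)cc1` differs from compound 3 in one place: methoxy in place of ((2-carboxyethyl)carbonyl)amino on an aromatic carbon. Going by the values given here, no measured pair shows this exact change. Smaller groups at this place, in compound 1 and compound 2, gave numbers rather than a limit, so a move toward less tolerance is expected, an at least 3.3-fold lower number from compound 3 to compound 4 (0.52 log units; beyond the scatter). Compound 4 is estimated at 30000 nM, between 8000 nM and 100000 nM.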

Compound 4, half-maximal cytotoxic concentration: > 100000 nM
Compound 4: a limit, no number; the forecaster's own chance of this, stated with the estimate: 20%; at least 3.3-fold (0.52 log units) between middle value and limit.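

Compound 3 and compound 4 each carry only a limit in this assay, so no step between them can be read: the limit of > 100000 nM in this assay, at which 2 of the 4 values shown sit.

The compounds shown leave open whether methoxy or ((2-carboxyethyl)carbonyl)amino is the better tolerated group at this place.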